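The source may hold more compounds than are shown below. What is called first, only, known or untested is meant among the compounds shown, and "the series" means these compounds.

Measured compounds in a functional assay on HEK293 cells for agonist activity at Bombesin receptor subtype-3 (Homo sapiens), read by luminescence and calcium flux, with a stated time of 10 min; a higher number here means that more compound is needed for the effect, a lower number that less compound is needed:

Compound 1, `CCC(C)(C)Cc1c[nH]c(CCc2ccc(-c3cccc(C)n3)cc2)n1`: 102 nM
Compound 2, `CCC(C)(C)Cc1c[nH]c(CCc2ccc(-c3cnccn3)cc2)n1`: 100 nM
Compound 3, `CCC(C)(C)Cc1c[nH]c(CCc2ccc(-c3cnsc3)cc2)n1`: 100 nM

Compound 1 holds the highest of the three numbers, but only by a margin that is within the scatter: the step of a 1.0-fold lower number from compound 1 to compound 2 (0.01 log units; within the scatter) and the step of a 1.0-fold lower number from compound 1 to compound 3 (0.01 log units; within the scatter) are both too small to count as real differences, and the same holds for no change at the digits printed from compound 2 to compound 3 (within the scatter). In other words, the three compounds behave alike.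

Compound 4, `CCC(C)(C)Cc1c[nH]c(CCc2ccc(-c3ccns3)cc2)n1`, is the next compound. Compared with compound 1, the change is this: 1,2-thiazol-5-yl in place of 6-methylpyridin-2-yl on an aromatic carbon. Among the compounds with values here, the steps that bear on it are those from compound 1 to compound 2 and from compound 1 to compound 3, where the same group was exchanged for other small aromatic rings and nothing beyond the scatter followed. Compound 4 is therefore expected to show a 1.0-fold lower number from compound 1 to compound 4 (0.01 log units; within the scatter), that is, no step beyond the scatter. The estimate for compound 4 in this assay is 100 nM, with a range from 40 nM to 250 nM.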

Compound 4, half-maximal effective concentration: 102 nM
Estimate against measurement, compound 4: 1.0-fold (0.01 log units) below; measured number inside the range.
By their numbers in this assay, from the lowest: compounds 2, 3, 1 and 4 (each within the scatter of the next).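

In this assay, a five-membered ring with sulfur serves here as well as a six-membered ring with a methyl group: 1,2-thiazol-5-yl in place of 6-methylpyridin-2-yl gives no change at the digits printed from compound 1 to compound 4 (within the scatter) and thus adds to the flat picture at this place on the aromatic ring. The new information is that the way the thiazole ring is attached also makes no visible difference, with a 1.0-fold higher number from compound 3 to compound 4 (0.01 log units; within the scatter) between the two isomers, and the swap from pyrazin-2-yl gives a 1.0-fold higher number from compound 2 to compound 4 (0.01 log units; within the scatter) as well. No independent evidence is available to explain this flat result.

From the compounds shown here alone, all four groups at this place are small aromatic rings, so it remains open whether a carboxylic acid, an amine or a morpholine ring would give a similar value. Changes elsewhere on the shared core also remain open.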